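The compounds below may be only part of what the source reports. "The series", "measured", "known", "first", "only" and "open" are said of these compounds alone.

Working notes on the hydroxamic acid series in an assay on Sf9 cells for inhibition of protein deacetylase HDAC6 (Homo sapiens), read by fluorescence, with a stated time of 40 min, tested at 100 nM; on this read-out higher numbers stand for more inhibition at the one concentration tested (going by the name of the read-out) and lower numbers for less inhibition.

Three compounds share one core and differ only in the aryl group on an aromatic carbon of the five-membered ring with three nitrogen atoms. Compound 1 `Cc1ccccc1-c1nc(CNc2ccc(C(=O)NO)cc2)n(-c2ccccc2)n1` gives 53.2%. Compound 2 `O=C(NO)c1ccc(NCc2nc(-c3ccccc3Cl)nn2-c2ccccc2)cc1` gives 75%. Compound 3 `O=C(NO)c1ccc(NCc2nc(-c3ccc(C(F)(F)F)cc3)nn2-c2ccccc2)cc1` gives 41.6%, the lowest of the three numbers; compound 1 is nearest and compound 2 furthest, both beyond the scatter. The steps measured at this position are a number 21.8 percentage points higher from compound 1 to compound 2 (beyond the scatter), a number 11.6 percentage points lower from compound 1 to compound 3 (beyond the scatter) and a number 33.4 percentage points lower from compound 2 to compound 3 (beyond the scatter).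

Compound 4 `Cc1ccc(-c2nc(CNc3ccc(C(=O)NO)cc3)n(-c3ccccc3)n2)s1` has not yet been measured. It differs from compound 3 by 5-methylthiophen-2-yl in place of 4-(trifluoromethyl)phenyl on an aromatic carbon. Both steps that end at compound 3 bear on this change, since each replaces the aryl group at the same carbon: the step from compound 2 was large, that from compound 1 modest, and both point downward toward compound 3. A smaller, two-ring-bond aryl group entering in place of the largest group among the measured compounds is therefore expected to give a modest step upward in this assay, estimated as a number 10.4 percentage points higher from compound 3 to compound 4 (beyond the scatter). Compound 4 is expected to give about 52%, within a range of 35% to 70%.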

Compound 4, a percentage reported as inhibition, at one concentration (the size of the read-out at that concentration, not a potency): 79.7%
Compound 4: middle estimate off by 27.7 percentage points, on the low side; measured number outside the range, above it.
By their numbers in this assay, from the lowest: compound 3; then compound 1; then compounds 2 and 4 (each within the scatter of the next).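

In this assay, among the compounds shown here, a number 38.1 percentage points higher from compound 3 to compound 4 (beyond the scatter) and a number 26.5 percentage points higher from compound 1 to compound 4 (beyond the scatter) show that this aromatic carbon can carry a five-membered aromatic ring with 1 hetero atom, whereas the earlier compounds offered only substituted six-membered aromatic rings of carbon. With a number 4.7 percentage points higher from compound 2 to compound 4 (within the scatter) in the same assay, 5-methylthiophen-2-yl and 2-chlorophenyl cannot be told apart here, so two different ring types now share the top of this short series, and a high number at this carbon does not depend on a phenyl ring. Nothing available explains why 5-methylthiophen-2-yl differs so much from 4-(trifluoromethyl)phenyl.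

The compounds shown leave open whether the methyl on the thiophene contributes anything, which an unsubstituted thiophen-2-yl or a 5-chlorothiophen-2-yl would test, and whether a pyridine ring or a phenyl ring bearing an amine or a carboxylic acid would fit this carbon as well. They also leave open what happens when the phenyl group on the neighbouring ring atom is changed, and, as each number comes from one concentration, how compound 2 and compound 4 compare in potency.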